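A few compounds are considered here, and "the series" means these few. Any claim that something is new, unique, unknown or untested is made for them only; others in the source may bear on it.

Measured compounds and their values in a physicochemical assay for lipophilicity; a lower number here means a more polar compound, a higher number a more lipophilic compound:
compound 1, `CCOC(=O)C1=C(C)NC(=S)NC1c1cn(C(=O)CNc2ccc([N+](=O)[O-])c(Cl)c2)c2ccccc12`, 3.4;
compound 2, `CCOC(=O)C1=C(C)NC(=O)NC1c1cn(C(=O)CNc2ccccc2[N+](=O)[O-])c2ccccc12`, 1.48;
compound 3, `CCOC(=O)C1=C(C)NC(=O)NC1c1cn(C(=O)CNc2cccc([N+](=O)[O-])c2)c2ccccc12`, 1.48.

Compound 3 stands level with compound 2 in this assay; together they give the lowest of the three numbers, and compound 1 lies well above both. Compound 1 differs from compound 3 in two places at once, so its value tells nothing about either change on its own.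

Compound 4, `CCOC(=O)C1=C(C)NC(=O)NC1c1cn(C(=O)CNc2ccc(Cl)cc2)c2ccccc12`, is not yet measured. It differs from compound 3 in one place: 4-chlorophenyl in place of 3-nitrophenyl on an amine nitrogen. Among the measured compounds shown here, only one measured step touches this position, no change at the digits printed from compound 2 to compound 3 (within the scatter); it moved the nitro group from one position to another on the same ring and left the partition coefficient unchanged. For the measured compounds named here, no measured pair shows the exchange of a nitro group for a chlorine, so the direction and size of this step are not fixed by the data.

Compound 4 is nevertheless expected to come out higher than compound 3, with an estimated step of a number 0.82 log units higher from compound 3 to compound 4 (beyond the scatter). The expected value for compound 4 is 2.3, between 1.6 and 3.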

Compound 4, partition coefficient: 2.04
The estimate for compound 4 lay 0.26 log units above the measured number; the measured number falls inside the stated range.
By their numbers in this assay, from the lowest: compounds 2 and 3 (each within the scatter of the next); then compound 4; then compound 1.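

In this assay, this position on the amine nitrogen now shows a real response: putting 4-chlorophenyl in place of 3-nitrophenyl gives a number 0.56 log units higher from compound 3 to compound 4 (beyond the scatter). Among the compounds shown here, putting it in place of 2-nitrophenyl gives the same reading, a number 0.56 log units higher from compound 2 to compound 4 (beyond the scatter), whereas the only earlier step here, no change at the digits printed from compound 2 to compound 3 (within the scatter), showed no movement, so exchanging the nitrophenyl group for 4-chlorophenyl shifts the partition coefficient where relocating the nitro group did not. No measurement is available that explains this rise.

The 4-chlorophenyl group differs from both nitrophenyl groups in its substituent and in where that substituent sits on the ring, so the compounds shown cannot separate these two changes. As far as these compounds go, how a plain phenyl group, or a phenyl ring carrying an amine or a methoxy group, would read on this nitrogen remains open, as does whether the step would hold on the core of compound 1.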